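The source may hold more compounds than are shown below. What is called first, only, known or untested is meant among the compounds shown, and "the series" means these compounds.

Of the compounds shown here, three that share one core have been measured in an assay for inhibition of Fatty-acid amide hydrolase 1 (Rattus norvegicus), using a Dixon plot, with a stated time of 3 h; a lower number here means a stronger inhibitor, a higher number a weaker inhibitor. Compound 1 `CCOS(=O)(=O)/C=C/c1ccc(-c2cnc(C(=O)CCCCCCc3ccccc3)o2)nc1` gives 0.3 nM, compound 2 `C[S+]([O-])/C=C/c1ccc(-c2cnc(C(=O)CCCCCCc3ccccc3)o2)nc1` gives 1 nM, and compound 3 `CSC(=O)CCCCc1cnc(C(=O)CCCCCCc2ccccc2)o1` gives 1.4 nM. Compound 3 thus carries the highest of the three numbers: its gap to compound 2 lies within the scatter, while its gap to compound 1 lies beyond it. For the measured compounds named here, the only step that can be read between two measured compounds, a 3.3-fold higher number from compound 1 to compound 2 (0.52 log units; beyond the scatter), concerns a group on the double-bonded chain and says nothing about the saturated chain of compound 3.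

Compound 4 `CSCCCCCc1cnc(C(=O)CCCCCCc2ccccc2)o1` has not yet been measured in this assay. It differs from compound 3 by (methylsulfanyl)methyl in place of (methylsulfanyl)carbonyl on a saturated chain carbon, four bonds along the chain from an aromatic carbon. Going by the values given here, no measured step bears on this change: the one step that exists swaps one chain group for another and leaves every carbonyl in place. The size and direction of the effect of removing the carbonyl from the chain of compound 3 therefore cannot be read from the numbers shown.

Compound 4 is expected, with wide uncertainty, to give about 5 nM, with a range from 1.2 nM to 25 nM. The corresponding step is estimated at a 3.6-fold higher number from compound 3 to compound 4 (0.55 log units; beyond the scatter), a rise in number being judged somewhat more likely than a fall.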

Compound 4, inhibition constant: 6.4 nM
Compound 4: the middle estimate sits 1.3-fold (0.11 log units) below what was measured, and the stated range covers the measured number.
By their numbers in this assay, from the lowest: compound 1; then compounds 2 and 3 (each within the scatter of the next); then compound 4.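

In this assay, (methylsulfanyl)methyl in place of (methylsulfanyl)carbonyl on a saturated chain carbon, four bonds along the chain from an aromatic carbon, gives a 4.6-fold higher number from compound 3 to compound 4 (0.66 log units; beyond the scatter). For the compounds shown here, this is the first step that can be read on the saturated chain, and it shows that removing the carbonyl there, which also removes one hydrogen-bond acceptor by count, raises the number modestly without abolishing inhibition, as compound 4 still gives 6.4 nM. No measurement shown here explains why the number rises with this change.

The pair alone cannot separate the loss of the carbonyl from any other difference between the two chain ends, and it leaves open how an ester, an amide, a carboxylic acid or a simple methyl group at the same place would compare with (methylsulfanyl)carbonyl and (methylsulfanyl)methyl. It also leaves open whether a shorter or longer chain would keep a step of this size and direction, or whether the same change would have a similar effect elsewhere on the shared core.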